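This account rests on a few compounds, and the source may have more. Where it says the series, first, only, none or still open, it means among the compounds named here.

Measured so far:
compound 1 `CN(C)C/C=C(/c1ccccc1)c1cccnc1`: 107 umol/kg
compound 2 `CN(C)C/C=C(\c1cccnc1)c1cccc(F)c1`: 33 umol/kg

In an in vivo functional assay on the whole organism (brain) for inhibition of Norepinephrine transporter (Rattus norvegicus) (a lower number here means that less compound is needed, a higher number that more compound is needed for the effect), compound 2 gives 33 umol/kg, the lowest of the two numbers. Its nearest neighbour is compound 1, which gives 107 umol/kg; the step of a 3.2-fold lower number from compound 1 to compound 2 (0.51 log units; beyond the scatter) lies beyond the scatter.

Compound 3 `CN(C)C/C=C(\c1cccnc1)c1cccc(Cl)c1` differs from compound 2 by chloro in place of fluoro on an aromatic carbon. Among the measured compounds shown here, the only step measured here, a 3.2-fold lower number from compound 1 to compound 2 (0.51 log units; beyond the scatter), concerns fluoro in place of hydrogen and not chloro in place of fluoro, so it bears on the new change only in showing that this position tolerates a halogen; no measured pair shows chloro against fluoro. For compound 3 the expected step is therefore a 1.3-fold lower number from compound 2 to compound 3 (0.12 log units; within the scatter), small and within the usual scatter, with a slight lean toward a lower number. Compound 3 is estimated at 25 umol/kg, with a range from 10 umol/kg to 70 umol/kg.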

Compound 3, dose for half-maximal effect: > 110 umol/kg
Compound 3 gave a limit, no number; the forecaster's own chance of this, stated with the estimate: 5%; at least 4.4-fold (0.64 log units) between middle value and limit.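

In this assay, among the compounds shown here, the earlier compounds showed only that fluoro in place of hydrogen on this aromatic carbon goes with a lower number, and the new result shows that the halogens are not interchangeable here: an at least 3.3-fold higher number from compound 2 to compound 3 (0.52 log units; beyond the scatter) marks chloro in place of fluoro as a move the other way. Against hydrogen the reading is weaker, as an at least 1.0-fold higher number from compound 1 to compound 3 (0.01 log units; that floor lies within the scatter) gives only a floor, so chloro shows no gain over hydrogen, but how far the change goes beyond that floor stays unknown. Compound 3 stands at a limit of the assay and not at a number: the limit of > 110 umol/kg in this assay, at which 1 of the 3 values shown sits.

As far as these compounds go, whether a methoxy group or a nitrile on this carbon would follow fluoro or chloro remains open. So does whether chloro would give the same result elsewhere on this ring.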